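Three limits and a fourth variant of the side ring

A few compounds are considered here, and "the series" means these few. Any claim that something is new, unique, unknown or untested is made for them only; others in the source may bear on it.

Compound 1, `Cc1ccc2c(NCc3ccc(NC(=O)C4CCN(Cc5cc(Cl)ccn5)CC4)cc3)nc(N(C)C)nc2c1`: > 5400 nM
Compound 2, `Cc1ccc2c(NCc3ccc(NC(=O)C4CCN(Cc5ccccc5)CC4)cc3)nc(N3CCC(N4CCCC4)CC3)nc2c1`: > 8090 nM
Compound 3, `Cc1ccc2c(NCc3ccc(NC(=O)C4CCN(Cc5ccc(F)cc5Cl)CC4)cc3)nc(N(C)C)nc2c1`: > 5910 nM

All three measured compounds were tested in a functional assay on SV5A8 cells (Homo sapiens) for cytotoxicity; on this read-out lower numbers stand for stronger inhibition and higher numbers for weaker inhibition. Compound 1 reached only the limit > 5400 nM there, which is a bound of the assay and not a number. Compound 3 likewise gave only the limit > 5910 nM. Compound 2 also gave only the limit > 8090 nM. Thus compound 1 stands at a limit among three limits, and the change from compound 1 to compound 3, a step that the two limits leave unreadable from compound 1 to compound 3, cannot be read in size or direction because both ends are limits (the limit of > 5400 nM in this assay, at which 1 of the 3 values shown sits, (the limit of > 5910 nM in this assay, at which 1 of the 3 values shown sits)).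

Compound 4, `Cc1ccc2c(NCc3ccc(NC(=O)C4CCN(Cc5ccc(F)cc5)CC4)cc3)nc(N(C)C)nc2c1`, differs from compound 1 by 4-fluorophenyl in place of 4-chloropyridin-2-yl on a saturated chain carbon bound to an amine nitrogen in a ring. Within the data shown here, the only measured step that bears on this place is the one from compound 1 to compound 3, and it is unreadable. With compound 1 and compound 3 both at limits, compound 4 is expected to show no readable step either, a step that the limit leaves unreadable from compound 1 to compound 4, and most probably another limit. The estimate for compound 4 in this assay is 6500 nM, within the range 2500 nM to 20000 nM.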

Compound 4, half-maximal inhibitory concentration: > 4820 nM
Compound 4 gave a limit, no number; the forecaster's own chance of this, stated with the estimate: 75%; the middle value lies beyond the limit too.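

In this assay compound 4 gave only > 4820 nM, which is a limit and not a number. With limits at both ends, neither its step from compound 1 nor its step from compound 3 can be read. The compounds shown leave open whether changing the side ring alters the read-out at all.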